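Cinnamide-type amides on a shared chromone core: cytotoxicity notes

This account rests on a few compounds, and the source may have more. Where it says the series, first, only, none or still open, it means among the compounds named here.

Measured so far:
compound 1 `COc1ccc2c(=O)c(/C=C/C(=O)Nc3cc(C)ccc3C)coc2c1`: 1100000 nM
compound 2 `COc1ccc2c(=O)c(/C=C/C(=O)Nc3ccccc3)coc2c1`: 523000 nM
compound 3 `Cc1ccccc1NC(=O)/C=C/c1coc2cc(O)ccc2c1=O`: 374000 nM

In an ADME assay on HepG2 2.2.15 cells (Homo sapiens) for cytotoxicity, read by MTT assay, with stated times of 48 h and 9 days (a lower number here means that less compound is tolerated, a higher number that more compound is tolerated), compound 2 stands second highest of the three numbers; compound 3 lies within the scatter of it, while compound 1 sits beyond the scatter on the higher side. Going by the values given here, the only step touching the amide-type nitrogen is a 2.1-fold lower number from compound 1 to compound 2 (0.32 log units; beyond the scatter), a modest one. Compound 4 `COc1ccc2c(=O)c(/C=C/C(=O)NCc3ccc(C)cc3)coc2c1` is not yet measured in this assay; it differs from compound 2 as follows: 4-methylbenzyl in place of phenyl on an amide-type nitrogen. Among the compounds with values here, since adding substituted carbon on this nitrogen went with a higher number in the one step available, a small shift upward is expected for compound 4. The estimated step is a 1.3-fold higher number from compound 2 to compound 4 (0.13 log units; within the scatter), and it may well stay within the scatter. Compound 4 is therefore estimated at 700000 nM, with a range of 300000 nM to 1500000 nM.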

Compound 4, half-maximal cytotoxic concentration: 257000 nM
Compound 4: the middle estimate sits 2.7-fold (0.44 log units) above what was measured; measured number below the stated range.
By their numbers in this assay, from the lowest: compounds 4, 3 and 2 (each within the scatter of the next, the first and the last beyond it); then compound 1.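

Going by these compounds alone, at this amide-type nitrogen, added carbon does not go with a higher number in this assay: 4-methylbenzyl in place of phenyl gives a 2.0-fold lower number from compound 2 to compound 4 (0.31 log units; beyond the scatter) and so runs opposite to the one earlier step. Set against 2,5-dimethylphenyl, the same group gives a 4.3-fold lower number from compound 1 to compound 4 (0.63 log units; beyond the scatter) and places compound 4 clearly under compound 1 on this nitrogen. Nothing at hand explains the reversal.

From the compounds shown here alone, whether the lower number belongs to the benzyl part or to its methyl stays open. Plain benzyl or a phenethyl chain on this nitrogen would bear on that.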